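The source may hold more compounds than are shown below. What is called first, only, known or untested is meant among the compounds shown, and "the series" means these compounds.

In an ADME assay on microsomes from liver (Rattus norvegicus) for metabolic stability, with a stated time of 10 min (on this read-out lower numbers stand for a less stable compound and higher numbers for a more stable compound), compound 1 `FC(F)(F)c1ccccc1-c1cc(Cl)c2[nH]c(C3=NOC4(CCCCC4)C3)nc2c1` gives 100% and compound 2 `N#Cc1cc(-c2ccccc2C(F)(F)F)cc2nc(C3=NOC4(CCCCC4)C3)[nH]c12` gives 96%. For the measured compounds named here, these are the only two numbers so far, and they lie within the usual scatter of each other, so compound 2 cannot be ranked apart from compound 1.

The next compound, compound 3 `FC(F)(F)c1ccccc1-c1cc(Br)c2[nH]c(C3=NOC4(CCCCC4)C3)nc2c1`, has not yet been measured. It differs from compound 2 in one place, with bromo in place of cyano on an aromatic carbon. That carbon is part of a fused system of two rings, and it lies meta to a 2-(trifluoromethyl)phenyl group.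

Going by the values given here, only one measured step bears on this change, because it involves the same place: a number 4 percentage points lower from compound 1 to compound 2 (within the scatter). Among the compounds with values here, that single step is small, but it says nothing directly about bromo, which has not been tested in any compound so far. No change beyond the scatter is therefore expected in this assay, and no direction can be favoured. The estimated step is a number 1 percentage points lower from compound 2 to compound 3 (within the scatter). For compound 3 the expected value is 95%, with an estimated range from 82% to 100%.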

Compound 3, percent of the compound remaining: 83%
For compound 3 the middle estimate is 12 percentage points above the measured one, within the range that was stated.
By their numbers in this assay, from the lowest: compound 3; then compounds 2 and 1 (each within the scatter of the next).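

On this aromatic carbon, ortho to a fused ring, bromo in place of cyano gives a number 13 percentage points lower from compound 2 to compound 3 (beyond the scatter) and bromo in place of chloro gives a number 17 percentage points lower from compound 1 to compound 3 (beyond the scatter) in this assay as the read-out. For the compounds shown here, the only earlier change at this place, cyano in place of chloro, stayed within the scatter, so the position could have seemed indifferent to what stands on it; bromo now shows that the choice of group here can shift the amount of compound remaining, although both steps are modest. No measurement at hand explains why bromo separates from chloro and cyano in this way.

Going by these compounds, three groups at one position form a very short series, so it remains open how an amine, a methoxy group, a carboxylic acid or a longer chain on this carbon would compare. It also remains open whether bromo would give a similar step with something other than the 2-(trifluoromethyl)phenyl group on the shared core, since every compound shown carries that same group.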